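A Methyl Branch on the Chain, Tried on Two Cores

This account rests on a few compounds, and the source may have more. Where it says the series, first, only, none or still open, it means among the compounds named here.

Compound 1 `CC/C=C/C(=O)Nc1cc2c(N3CCc4ccccc43)ncnc2cc1OC` and compound 2 `COc1cc2ncnc(N3CCc4ccccc43)c2cc1NC(=O)/C=C/C(C)C` share one core and differ in a single place: methyl in place of hydrogen on a saturated chain carbon bound to a double-bonded chain carbon and a saturated chain carbon. In a functional assay on MCF7 cells (Homo sapiens) for antiproliferative activity, read by MTT assay, with a stated time of 72 h (on this read-out lower numbers stand for stronger inhibition and higher numbers for weaker inhibition), compound 1 gives 4030 nM, and compound 2 gives 6780 nM. The step between them is a 1.7-fold higher number from compound 1 to compound 2 (0.23 log units; within the scatter), so these two numbers cannot be told apart with any confidence.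

Compound 3 `CC/C=C/C(=O)Nc1cc2c(N3CCCc4ccccc43)ncnc2cc1O[C@@H]1CCOC1` is built on a different core; the difference between the two cores is not broken down here. In this assay compound 3 gives 14400 nM, the highest of the three numbers, with a gap beyond the scatter to both compound 1 and compound 2.

Compound 4 `CC(C)/C=C/C(=O)Nc1cc2c(N3CCCc4ccccc43)ncnc2cc1O[C@@H]1CCOC1` is compound 3 carrying the same change that turned compound 1 into compound 2: methyl in place of hydrogen on a saturated chain carbon bound to a double-bonded chain carbon and a saturated chain carbon. The surroundings of the change are described in the same words in both pairs, so the change itself is the same; only the core it sits on differs.

Because the earlier step was a 1.7-fold higher number from compound 1 to compound 2 (0.23 log units; within the scatter), the expectation for compound 4 is a step of similar size, a 1.7-fold higher number from compound 3 to compound 4 (0.22 log units; within the scatter), rather than a large shift in either direction. Compound 4 is therefore estimated at 24000 nM in this assay, with a likely range from 11000 nM to 50000 nM. Whether a second core answers the branch the same way as the first is what the measurement will show.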

Compound 4, half-maximal inhibitory concentration: 4680 nM
The estimate for compound 4 lay 5.1-fold (0.71 log units) above the measured number; the whole stated range lies above it.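

In this assay the new step is a 3.1-fold lower number from compound 3 to compound 4 (0.49 log units; beyond the scatter), so on the core of compound 3 the change from ethyl to isopropyl goes with stronger inhibition. Set beside the earlier step, the same methyl does not carry over from one core to the other with the same effect: the same change on two cores in this assay, a 1.7-fold higher number (0.23 log units; within the scatter) from compound 1 to compound 2 and a 3.1-fold lower number (0.49 log units; beyond the scatter) from compound 3 to compound 4, 5.2-fold (0.71 log units) apart, beyond the scatter of two such steps This shows that, in this series, a step read on one core is a poor guide to the step on the other, but two pairs do not show which part of the cores accounts for the gap, since the difference between them is not broken down here.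

The compounds shown leave open how either core would answer if the saturated chain carbon bore a longer chain, or if an amine stood on the chain in place of the methyl. They also leave open whether a third core would follow the pair of compound 1 and compound 2, the pair of compound 3 and compound 4, or neither.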